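This account rests on a few compounds, and the source may have more. Where it says the series, first, only, none or still open, it means among the compounds named here.

Compound 2 `N=C(Nc1cccc(C(F)(F)F)c1)c1cc2c(-c3ccccc3)n[nH]c2cn1` is a benzamidine-type compound carrying a trifluoromethyl group on the aniline ring. In a functional assay on HT-1080 cells (Homo sapiens) for cytotoxicity, read by MTT assay, with a stated time of 72 h (a higher number here means a weaker inhibitor, a lower number a stronger inhibitor), compound 2 gives 24600 nM. Its number sits together with those of its neighbours: compound 3 `N=C(Nc1ccccc1)c1cc2c(-c3ccccc3)n[nH]c2cn1` gives 22000 nM, and compound 1 `CN1CCN(c2ccc(NC(=N)c3cc4cn(C)nc4cn3)cc2)CC1` gives 21000 nM; the three values lie within the usual scatter of one another, so no order among them can be read.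

Among the measured compounds shown here, the one measured step in the set, a 1.1-fold lower number from compound 2 to compound 3 (0.05 log units; within the scatter), touches the aniline ring, not the position changed here. Compound 4 `COc1ccc(Cn2nc(-c3ccccc3)c3cc(C(=N)Nc4cccc(C(F)(F)F)c4)ncc32)cc1` differs from compound 2 in a single place: 4-methoxybenzyl in place of hydrogen on an aromatic nitrogen. Compound 1, which carries a methyl group on an aromatic nitrogen of its own core, and compound 3 differ in more than one place, so their two values show only that both sit in the same range as compound 2. For the measured compounds named here, no measured step bears directly on the entering 4-methoxybenzyl group, and the only step available stayed within the scatter. The expectation for compound 4 is therefore a step of about a 1.1-fold lower number from compound 2 to compound 4 (0.05 log units; within the scatter), that is, no change beyond the scatter, with a wide range to reflect the lack of a matching step. Compound 4 is expected to give 22000 nM in this assay, estimated between 7000 nM and 70000 nM.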

Compound 4, half-maximal inhibitory concentration: 46700 nM
For compound 4 the middle estimate is 2.1-fold (0.33 log units) below the measured one; the measured number falls inside the stated range.
By their numbers in this assay, from the lowest: compounds 1, 3, 2 and 4 (each within the scatter of the next, the first and the last beyond it).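

The aromatic nitrogen of the five-membered ring now has its first measured step: in this assay, 4-methoxybenzyl in place of hydrogen gives a 1.9-fold higher number from compound 2 to compound 4 (0.28 log units; within the scatter) and so no change that can be read. For this pair, therefore, the ring nitrogen does not need to keep its hydrogen for the number to stay within the scatter, and the added aromatic ring is accepted at this position without a clear loss. No supporting data are available to explain this result.

On these data alone, whether the same holds with a small group such as ethyl on this nitrogen, or with a longer chain ending in an amine or a carboxylic acid, remains open. Also open, as far as these compounds go, is whether 4-methoxybenzyl would behave the same way on compound 3, with hydrogen in place of trifluoromethyl on the aniline ring.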